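Ethyl for tert-butyl on the anilino ring: an expectation

A few compounds are considered here, and "the series" means these few. Any claim that something is new, unique, unknown or untested is made for them only; others in the source may bear on it.

Measured compounds:
compound 1, `Cc1ccc(Nc2cc(NC(=O)Nc3c(Cl)cccc3Cl)ncn2)cc1F`, 33.5%
compound 2, `COc1ccc(Nc2cc(NC(=O)Nc3c(Cl)cccc3Cl)ncn2)cc1C`, 29.1%
compound 3, `CC(C)(C)c1ccc(Nc2cc(NC(=O)Nc3c(Cl)cccc3Cl)ncn2)cc1`, 22%

Three compounds sharing one core were read in a functional assay on NCI-H520 cells (Homo sapiens) for inhibition, read by MTT assay, with a stated time of 48 h, tested at 10 uM; on this read-out lower numbers stand for less inhibition and higher numbers for more inhibition at the one concentration tested (going by the name of the read-out). Compound 1 gives 33.5%, compound 2 gives 29.1% and compound 3 gives 22%. Compound 3 lies beyond the scatter from compound 1 but within the scatter of compound 2, so its place at the low end of the three numbers is only firm against compound 1.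

Within the data shown here, the only single-point step among the measured compounds is a number 4.4 percentage points lower from compound 1 to compound 2 (within the scatter), a change of the substituents on the anilino ring that stays within the scatter. Compound 4, `CCc1ccc(Nc2cc(NC(=O)Nc3c(Cl)cccc3Cl)ncn2)cc1`, differs from compound 3 by ethyl in place of tert-butyl on an aromatic carbon, again a change of a substituent on that anilino ring. Among the measured compounds shown here, no measured pair isolates an exchange of one alkyl group for another, so the one step that exists bears only loosely, and it was small.

Compound 4 is therefore expected to show no step beyond the scatter, a number 4 percentage points higher from compound 3 to compound 4 (within the scatter), in this assay. The estimate for compound 4 is 26%, within 14% to 38%.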

Compound 4, a percentage reported as inhibition, at one concentration (the size of the read-out at that concentration, not a potency): 31.5%
Beside the measured number, compound 4's estimate is 5.5 percentage points below it; the range from low to high includes it.
By their numbers in this assay, from the lowest: compounds 3, 2, 4 and 1 (each within the scatter of the next, the first and the last beyond it).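

In this assay, among these compounds, the exchange of tert-butyl for ethyl at this aromatic carbon, para to a large group, gives the first step that isolates one alkyl group against another: a number 9.5 percentage points higher from compound 3 to compound 4 (within the scatter) stays within the scatter, so going from 4 heavy atoms to 2 at this place has no firm effect on the read-out. Among the compounds shown here, the ethyl compound also fails to separate from the two other anilino compounds, as a number 2.4 percentage points higher from compound 2 to compound 4 (within the scatter) and a number 2 percentage points lower from compound 1 to compound 4 (within the scatter) both stay within the scatter, which leaves the gap between compound 3 and compound 1 as the only one beyond it while compound 4 lies within the scatter of all three. Nothing measured alongside these numbers offers a reason for them.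

The compounds shown carry only small carbon, fluoro and methoxy groups on this ring, so it remains open whether an amine, a carboxylic acid or a longer chain at this aromatic carbon would produce a step beyond the scatter. Also open, as far as these compounds go, is whether the small differences at this one concentration would hold up as differences in potency across a full concentration range.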